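The source may hold more compounds than are shown below. What is called first, only, known or untested is meant among the compounds shown, and "the series" means these compounds.

Of the compounds shown here, two built on the shared core have been measured in a functional assay on DU-145 cells (Homo sapiens) for cytotoxicity; on this read-out higher numbers stand for weaker inhibition and lower numbers for stronger inhibition. Compound 1 `COc1ccc(Cn2cc(/C=N\NC(=O)c3c[nH]c4ccccc34)c3ccccc32)cc1` gives 43900 nM, and compound 2 `COc1ccc(Cn2cc(/C=N\NC(=O)c3c[nH]c4ccccc34)c3cc(OC)ccc32)cc1` gives 19100 nM. Among the measured compounds shown here, compound 2 thus stands lowest of the two numbers; the only other compound is compound 1, and the change between them, methoxy in place of hydrogen on an aromatic carbon, gives a 2.3-fold lower number from compound 1 to compound 2 (0.36 log units; beyond the scatter). Compound 3 `COc1ccc(Cn2cc(/C=N\NC(=O)c3c[nH]c4ccc(Br)cc34)c3cc(OC)ccc32)cc1` has not been measured. It differs from compound 2 by bromo in place of hydrogen on an aromatic carbon, which turns the 1H-indol-3-yl part into 5-bromo-1H-indol-3-yl. For the measured compounds named here, no measured step touches this part of the molecule; the single measured step, a 2.3-fold lower number from compound 1 to compound 2 (0.36 log units; beyond the scatter), concerns a different ring, so it offers only a loose guide. In this assay a small to modest step is therefore expected, more likely toward a lower number than a higher one. Compound 3 is estimated to give 12000 nM in this assay, within 4000 nM to 40000 nM. That estimate corresponds to an expected 1.6-fold lower number from compound 2 to compound 3 (0.20 log units; within the scatter).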

Compound 3, half-maximal inhibitory concentration: 84400 nM
Compound 3: middle estimate off by 7.0-fold (0.85 log units), on the low side; the whole stated range lies below it.
By their numbers in this assay, from the lowest: compound 2; then compounds 1 and 3 (each within the scatter of the next).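

In this assay the change from 1H-indol-3-yl to 5-bromo-1H-indol-3-yl gives a 4.4-fold higher number from compound 2 to compound 3 (0.65 log units; beyond the scatter) and so weakens inhibition, which shows that this part of the molecule affects the read-out. The earlier step, a 2.3-fold lower number from compound 1 to compound 2 (0.36 log units; beyond the scatter), lay in a different ring and went the opposite way, so the direction of a change at one place cannot be carried over to another place on these compounds. No available evidence explains the effect of bromo at this position.

The compounds shown leave open whether fluoro, chloro, methoxy or an amine at this same place would also raise the number, or whether bromo is a special case. They also leave open whether bromo would have the same effect without the methoxy group that separates compound 2 from compound 1.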